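This account rests on a few compounds, and the source may have more. Where it says the series, first, only, none or still open, it means among the compounds named here.

In a functional assay on A-375 cells (Homo sapiens) for inhibition, read by CCK-8 assay, with a stated time of 72 h, tested at 8 uM (on this read-out higher numbers stand for more inhibition of growth at the one concentration tested and lower numbers for less inhibition of growth), the three measured compounds stand as follows: compound 1 `Cc1cc(C)cc(SCc2ccc(/C=C/C(=O)Nc3ccccc3N)cc2)c1` gives 2.49%; compound 2 `Nc1ccccc1NC(=O)/C=C/c1ccc(CSc2ccc(Cl)cc2)cc1` gives 48.2%; compound 3 `Nc1ccccc1NC(=O)c1ccc(CSc2ccc(Cl)cc2)cc1` gives 48.6%.

Compound 2 and compound 3 carry the same (4-chlorophenyl)sulfanyl side group on different cores; how the two cores differ is not broken down here, and their two values lie close together. Between compound 2 and compound 1 the change is 3,5-dimethylphenyl in place of 4-chlorophenyl on a sulfur, and it made a number 45.7 percentage points lower from compound 2 to compound 1 (beyond the scatter).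

Compound 4 `Cc1cc(C)cc(SCc2ccc(C(=O)Nc3ccccc3N)cc2)c1` arises from compound 3 by 3,5-dimethylphenyl in place of 4-chlorophenyl on a sulfur, the same change at the same place. A step of similar size is expected here, a number 44.6 percentage points lower from compound 3 to compound 4 (beyond the scatter), because a number 45.7 percentage points lower from compound 2 to compound 1 (beyond the scatter) was seen on the core of compound 2. Compound 4 is therefore estimated at 4%, expected to fall between -8% and 22%.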

Compound 4, percent growth inhibition at one concentration: 74.7%
Compound 4: middle estimate off by 70.7 percentage points, on the low side; measured number outside the range, above it.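

In this assay, 3,5-dimethylphenyl in place of 4-chlorophenyl on a sulfur gave a number 26.1 percentage points higher from compound 3 to compound 4 (beyond the scatter), so the direction of the step seen on the other core did not carry over: the same change on two cores in this assay, a number 45.7 percentage points lower (beyond the scatter) from compound 2 to compound 1 and a number 26.1 percentage points higher (beyond the scatter) from compound 3 to compound 4, 71.8 percentage points apart, beyond the scatter of two such steps For these two pairs, the outcome of this change depends on the core that carries it, and a step read on one core gave a poor guide to the other. The data do not show why the two cores respond differently, and two cores give no rule for a third.

Still open, as far as these compounds go, is how each core would respond to other groups on the sulfur, such as plain phenyl or 4-methylphenyl. A pair with one of these groups on both cores would show whether the reversal is confined to 3,5-dimethylphenyl.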